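Flipping the ring stereocentre of a compound at the limit

The source may report more compounds than this note shows. Statements on the series, on what has been measured and on what is new or still open speak of the compounds shown alone.

Compound 3 `CN(C)C[C@H]1CNC(=O)O1` shows no measurable binding: in an assay on CHO cells for displacement of a labelled ligand from muscarinic acetylcholine receptor M5 (Homo sapiens) (a lower number here means a stronger inhibitor, a higher number a weaker inhibitor), compound 3 gives > 100000 nM, which is a limit of the assay rather than a number. Compound 1 `CN(C)C[C@H]1CN(C)C(=O)O1` gives > 100000 nM, also a limit. Compound 2 `CN(C)C[C@@H]1CN(C)C(=O)O1` gives > 100000 nM, again a limit. The step that the two limits leave unreadable from compound 1 to compound 2 therefore cannot be read, and neither can a step that the two limits leave unreadable from compound 1 to compound 3. Compound 4 `CN(C)C[C@@H]1CNC(=O)O1` differs from compound 3 only in configuration: the two compounds have the same atoms and bonds and differ only in configuration as drawn: 1 of 1 stereo elements differ; a stereocentre at a saturated ring carbon is drawn R in compound 3 and S in compound 4. Every value here sits at the limit of > 100000 nM in this assay, at which 3 of the 3 values shown sit, so the fact that compounds 1 and 2 differ only in the configuration as drawn cannot be read as an effect of any size. On this basis a step that the limit leaves unreadable from compound 3 to compound 4 with no change beyond the scatter is expected. Compound 4 is thus expected to remain at the limit, estimated at 300000 nM, between 100000 nM and 1000000 nM.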

Compound 4, inhibition constant: > 100000 nM
Compound 4: a limit, no number; the forecaster's own chance of this, stated with the estimate: 90%; the middle value is on the limit's open side.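

In this assay compound 4 gives > 100000 nM, a limit and not a number, so its steps from compound 2 and compound 3 cannot be read. Going by these compounds, with all four compounds at a limit, the effect of the ring configuration or the methyl on the amide-type nitrogen remains open.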